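Swapping Methyl for Isopropyl on the Most Potent Compound

The compounds below may be only part of what the source reports. "The series", "measured", "known", "first", "only" and "open" are said of these compounds alone.

Compound 2 `COc1ccc(CN2C(=O)C(=O)c3cc(-c4ccc(OC)cc4)ccc32)cc1` gives 30 nM in a functional assay on K562 cells (Homo sapiens) for antiproliferative activity, read by MTT assay, with a stated time of 48 h (on this read-out lower numbers stand for stronger inhibition and higher numbers for weaker inhibition), the lowest of the two numbers shown, while compound 1 `COc1ccc(-c2ccc3c(c2)C(=O)C(=O)N3C)cc1` gives 4980 nM. Among the measured compounds shown here, the one measured step, a 170-fold lower number from compound 1 to compound 2 (2.22 log units; beyond the scatter), concerns 4-methoxyphenyl in place of hydrogen on a saturated chain carbon bound to an amide-type nitrogen in a ring, a different place, so it says nothing about the change to compound 3 `COc1ccc(CN2C(=O)C(=O)c3cc(-c4ccc(OC(C)C)cc4)ccc32)cc1`: isopropyl in place of methyl on an oxygen on an aromatic ring. For the measured compounds named here, with no step to lean on, a shift beyond the scatter is not expected in this assay. Compound 3 is therefore estimated at 40 nM, between 10 nM and 160 nM, an expected step of a 1.3-fold higher number from compound 2 to compound 3 (0.12 log units; within the scatter).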

Compound 3, half-maximal inhibitory concentration: 310 nM
Compound 3: middle estimate off by 7.8-fold (0.89 log units), on the low side, and the stated range ends below it.
By their numbers in this assay, from the lowest: compound 2; then compound 3; then compound 1.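

Changing methoxy to isopropoxy on the 4-methoxyphenyl group is not a neutral swap: in this assay, the change gives a 10-fold higher number from compound 2 to compound 3 (1.01 log units; beyond the scatter). Among the compounds shown here, this shows that activity depends on the group attached to this oxygen, which the earlier compounds did not vary. With only methyl and isopropyl compared here, this is a single step rather than a trend. No available evidence explains the loss.

An ethyl group on this oxygen could show whether activity falls gradually between methyl and isopropyl. On these data alone, a hydroxyl or an amine in place of methoxy also remains open.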